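Adding a methyl to the amide of compound 3

The compounds below may be only part of what the source reports. "The series", "measured", "known", "first", "only" and "open" are said of these compounds alone.

compound 1 `CNC(=O)CNCc1ccc(OCc2cccc(Cl)c2)cc1` gives 48.6 mg/kg
compound 2 `CN(CC(N)=O)Cc1ccc(OCc2cccc(Cl)c2)cc1` gives 70 mg/kg
compound 3 `C[C@@H](NCc1ccc(OCc2ccccc2)cc1)C(N)=O` gives 17.1 mg/kg

In a functional assay on the whole organism with Mus musculus as the target, in the maximal electroshock model (a lower number here means that less compound is needed, a higher number that more compound is needed for the effect), compound 3 has the lowest number of the three, and its gaps to compound 1 and to compound 2 both lie beyond the scatter. The next structure, compound 4 `CNC(=O)[C@H](C)NCc1ccc(OCc2ccccc2)cc1`, differs from compound 3 by 1-(methylcarbamoyl)ethyl in place of 1-carbamoylethyl on an amine nitrogen and keeps everything else unchanged. Among the compounds with values here, only one measured step bears on this change, and only loosely. This is a 1.4-fold higher number from compound 1 to compound 2 (0.16 log units; within the scatter), which puts (carbamoylmethyl)(methyl)amino in place of ((methylcarbamoyl)methyl)amino and so is a different change. Compound 1 also carries a methylated amide and stands at 48.6 mg/kg in this assay, but it differs from compound 3 in more than one place. Within the data shown here, no measured pair isolates the methyl on the amide. The estimated 1.5-fold higher number from compound 3 to compound 4 (0.18 log units; within the scatter) is therefore small, leaning toward a higher number and not expected to clear the scatter. The estimate for compound 4 is 26 mg/kg with an expected range from 12 mg/kg to 56 mg/kg in this assay.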

Compound 4, dose for half-maximal effect: 7 mg/kg
Compound 4: middle estimate off by 3.7-fold (0.57 log units), on the high side; the measured number lies below the stated range.
By their numbers in this assay, from the lowest: compound 4; then compound 3; then compounds 1 and 2 (each within the scatter of the next).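

In this assay, 1-(methylcarbamoyl)ethyl in place of 1-carbamoylethyl on an amine nitrogen gives a 2.4-fold lower number from compound 3 to compound 4 (0.39 log units; beyond the scatter), so at this position the added methyl on the amide lowers the dose needed rather than merely being tolerated. Within the data shown here, this is the first measured step that isolates the methyl on the amide; compound 1 also carries that methyl, but it differs from compound 3 in more than one place, so its value could not show this effect. No available measurement accounts for the direction or size of this step.

Going by these compounds, whether an ethyl or a longer chain on the amide nitrogen continues this trend remains open. Also open, on these data alone, is how a carboxylic acid in place of the amide would read.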